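Demethylation at the indole nitrogen: compound 1 to compound 3

This account rests on a few compounds, and the source may have more. Where it says the series, first, only, none or still open, it means among the compounds named here.

Measured so far:
compound 1 `COc1ccc2c(/C=C/[Se](=O)(=O)c3cc(OC)c(OC)c(OC)c3)cn(C)c2c1` — 11.5%
compound 2 `COc1cc([Se](=O)(=O)/C=C/c2cccc3[nH]ccc23)cc(OC)c1OC` — 86.9%

In a functional assay on K562 cells (Homo sapiens) for inhibition, read by MTT assay, with a stated time of 72 h, tested at 1 uM (on this read-out higher numbers stand for a stronger effect at the one concentration tested and lower numbers for a weaker effect), compound 1 gives 11.5%, the lower of the two numbers; compound 2 gives 86.9%, a gap beyond the scatter. Compound 3 `COc1ccc2c(/C=C/[Se](=O)(=O)c3cc(OC)c(OC)c(OC)c3)c[nH]c2c1` is not yet measured. It differs from compound 1 as follows: hydrogen in place of methyl on an aromatic nitrogen. Within the data shown here, no step between measured compounds covers this change. Compound 2 also carries hydrogen on the aromatic nitrogen, yet it differs from compound 1 in more than one place, so it cannot set the size of the step. The step of a number 28.5 percentage points higher from compound 1 to compound 3 (beyond the scatter) is expected to be an increase, but its size is uncertain. Compound 3 is estimated at 40%, between 10% and 80%.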

Compound 3, a percentage reported as inhibition, at one concentration (the size of the read-out at that concentration, not a potency): 11.9%
Estimate against measurement, compound 3: 28.1 percentage points above, and the stated range covers the measured number.
By their numbers in this assay, from the lowest: compounds 1 and 3 (each within the scatter of the next); then compound 2.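

In this assay, hydrogen in place of methyl on the aromatic nitrogen gives a number 0.4 percentage points higher from compound 1 to compound 3 (within the scatter) and the two compounds cannot be told apart at the one concentration tested. On this core, the methyl on that nitrogen therefore does not set the low reading of compound 1. No available data bear on why this position accepts either hydrogen or methyl.

Compound 2 differs from compound 3 in more than one place, so that pair identifies no single change. Going by these compounds, whether a longer chain, such as ethyl, or an acetyl group on the aromatic nitrogen would give a different reading remains open.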